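Amide aryl swaps on a flavonol-type series in HepG2 cells

The source may hold more compounds than are shown below. What is called first, only, known or untested is meant among the compounds shown, and "the series" means these compounds.

Compound 1 `O=C(Nc1cccc(-c2oc3cc(-c4ccc(F)cc4)ccc3c(=O)c2O)c1)c1ccccc1F` gives 10100 nM in a functional assay on HepG2 cells (Homo sapiens) for antiproliferative activity, read by CCK-8 assay, with a stated time of 72 h; a higher number here means a weaker inhibitor, a lower number a stronger inhibitor.
Compound 2 `O=C(Nc1cccc(-c2oc3cc(-c4ccc(F)cc4)ccc3c(=O)c2O)c1)c1ccc(F)cc1` gives 9280 nM in this assay.
Compound 3 `O=C(Nc1cccc(-c2oc3cc(-c4ccc(F)cc4)ccc3c(=O)c2O)c1)c1ccc(Cl)cc1` gives 11000 nM in this assay.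

Compound 2 holds the lowest of the three numbers, but its neighbours sit within the scatter of it. Compound 4 `COc1ccccc1C(=O)Nc1cccc(-c2oc3cc(-c4ccc(F)cc4)ccc3c(=O)c2O)c1` differs from compound 2 by 2-methoxyphenyl in place of 4-fluorophenyl on a carbonyl carbon. Among the compounds with values here, two measured steps bear on this: a 1.1-fold lower number from compound 1 to compound 2 (0.04 log units; within the scatter) and a 1.2-fold higher number from compound 2 to compound 3 (0.07 log units; within the scatter), both changes on the same aryl ring of the amide, both within the scatter. The move to a methoxy group and a new ring position is not covered directly, so a step beyond the scatter is not expected in this assay. Compound 4 is therefore estimated at 9500 nM, with a range of 4500 nM to 20000 nM, meaning an expected step of a 1.0-fold higher number from compound 2 to compound 4 (0.01 log units; within the scatter).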

Compound 4, half-maximal inhibitory concentration: 14500 nM
Estimate against measurement, compound 4: 1.5-fold (0.18 log units) below; measured number inside the range.
By their numbers in this assay, from the lowest: compounds 2, 1, 3 and 4 (each within the scatter of the next).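

In this assay, the step from fluoro to methoxy on the same ring position stays within the scatter: a 1.4-fold higher number from compound 1 to compound 4 (0.16 log units; within the scatter). The same holds for the swaps from the other two aryl groups, a 1.6-fold higher number from compound 2 to compound 4 (0.19 log units; within the scatter) and a 1.3-fold higher number from compound 3 to compound 4 (0.12 log units; within the scatter), so this position on the carbonyl carbon now carries an oxygen-bearing group without a step beyond the scatter. No available evidence bears on this result.

Still open, as far as these compounds go, is whether an amine or a carboxylic acid on this aryl ring would shift the number beyond the scatter. The same question stands for a longer chain in place of the ring.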